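The source may hold more compounds than are shown below. What is called first, only, known or untested is meant among the compounds shown, and "the series" means these compounds.

Going by the values given here, in a physicochemical assay for lipophilicity, at pH 7.4 (a higher number here means a more lipophilic compound, a lower number a more polar compound), three compounds with a shared core have numbers so far. Compound 1 `CNC(=O)c1cc(C(=O)NC2CCOCC2)cn(Cc2ccccc2)c1=O` gives 2.8, compound 2 `CNC(=O)c1cccn(Cc2ccccc2)c1=O` gives 3, and compound 3 `CNC(=O)c1cc(C(=O)NC(C)C)cn(Cc2ccccc2)c1=O` gives 3.6, the highest of the three. Compound 4 `CNC(=O)c1cc(C(=O)NCCC(C)C)cn(Cc2ccccc2)c1=O` has not yet been measured. It differs from compound 3 in one place: isopentyl in place of isopropyl on an amide-type nitrogen. In words, this is isopentyl in place of isopropyl on an amide-type nitrogen.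

The most relevant measured step is at that same kind of nitrogen, where isopropyl in place of oxan-4-yl gives a number 0.80 log units higher from compound 1 to compound 3 (beyond the scatter). Isopropylcarbamoyl in place of hydrogen on an aromatic carbon gives a number 0.60 log units higher from compound 2 to compound 3 (beyond the scatter), a step of similar size. Hydrogen in place of (oxan-4-yl)carbamoyl gives only a number 0.20 log units higher from compound 1 to compound 2 (within the scatter), so the two larger steps both involve isopropyl entering. None of the three compounds shows the effect of isopropyl giving way to isopentyl, so this evidence is indirect. On these steps, a modest rise in this assay is expected, similar in size to the two larger steps. The estimated change is a number 0.60 log units higher from compound 3 to compound 4 (beyond the scatter). For compound 4, the expected value is 4.2, within an estimated range from 3.8 to 4.6.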

Compound 4, distribution coefficient: 4.8
The estimate for compound 4 lay 0.60 log units below the measured number; measured number above the stated range.
By their numbers in this assay, from the lowest: compounds 1 and 2 (each within the scatter of the next); then compound 3; then compound 4.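

In this assay the change from isopropyl to isopentyl on the amide-type nitrogen gives a number 1.20 log units higher from compound 3 to compound 4 (beyond the scatter) and so shows that this position still responds strongly after isopropyl: two more carbons in a chain with no ring and no hydrogen-bond donors or acceptors produce a step larger than the earlier a number 0.80 log units higher from compound 1 to compound 3 (beyond the scatter) at the same nitrogen. The other two comparisons widen the spread across the series, with isopentyl in place of oxan-4-yl giving a number 2.00 log units higher from compound 1 to compound 4 (beyond the scatter) and isopentylcarbamoyl in place of hydrogen on the aromatic carbon giving a number 1.80 log units higher from compound 2 to compound 4 (beyond the scatter), so the group on this nitrogen can move the number far beyond what compounds 1, 2 and 3 showed. No measurement shown here accounts for the size of the step from isopropyl to isopentyl.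

The compounds shown leave open whether a longer chain, such as hexyl, would raise the number further or whether the rise would level off, and whether a straight pentyl chain would behave like the branched isopentyl. They also leave open how far an amine or a carboxylic acid at the end of the chain would change the number.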